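Bromo in place of nitro in compound 2

The source may hold more compounds than are shown below. What is called first, only, known or untested is meant among the compounds shown, and "the series" means these compounds.

- compound 1 `C/C=C/C(=O)N(Cc1ccc(OC)c([N+](=O)[O-])c1)c1cc(OC)c(OC)c(OC)c1` gives 590 nM
- compound 2 `COc1ccc(CNc2cc(OC)c(OC)c(OC)c2)cc1[N+](=O)[O-]` gives 19400 nM
- compound 3 `C/C=C/C(=O)N(Cc1cc(OC)c(OC)c(OC)c1)c1ccc(OC)c(O)c1` gives 6150 nM

Compound 2 has the highest number of the three in a functional assay on MGC-803 cells (Homo sapiens) for inhibition, read by MTT assay, with a stated time of 48 h (a higher number here means a weaker inhibitor, a lower number a stronger inhibitor), and so is the weakest inhibitor here. Compound 4 `COc1ccc(CNc2cc(OC)c(OC)c(OC)c2)cc1Br` carries bromo in place of nitro on an aromatic carbon, ortho to a methoxy group, a change counted as bromo in place of nitro on an aromatic carbon with nothing else altered. Among the measured compounds shown here, the only measured step of a 33-fold higher number from compound 1 to compound 2 (1.52 log units; beyond the scatter) is large, but it concerns the (prop-1-en-1-yl)carbonyl on a nitrogen and leaves the nitro untouched. For the measured compounds named here, no measured step tests this swap, so no shift beyond the scatter is expected, in either direction. The expected step is a 1.3-fold lower number from compound 2 to compound 4 (0.11 log units; within the scatter) and remains uncertain. The expected value for compound 4 is 15000 nM with 4000 nM to 50000 nM as its estimated range.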

Compound 4, half-maximal inhibitory concentration: 29400 nM
Estimate against measurement, compound 4: 2.0-fold (0.29 log units) below; the range from low to high includes it.
By their numbers in this assay, from the lowest: compound 1; then compound 3; then compounds 2 and 4 (each within the scatter of the next).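

In this assay, bromo in place of nitro gives a 1.5-fold higher number from compound 2 to compound 4 (0.18 log units; within the scatter) and so makes no clear difference at this aromatic carbon, ortho to a methoxy group. Here, a single bromine atom with no hydrogen-bond acceptors reads the same as a nitro group of three heavy atoms with two acceptors. No outside information on this result is at hand to explain it. From the compounds shown here alone, it remains open whether the swap would be equally quiet with the (prop-1-en-1-yl)carbonyl on the nitrogen, as in compound 1. Going by these compounds, how an amine or a carboxylic acid would read at this carbon also remains open.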